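A few compounds are considered here, and "the series" means these few. Any claim that something is new, unique, unknown or untested is made for them only; others in the source may bear on it.

Compound 1, with the structure `Brc1ccccc1OCC1=NCCO1`, is one of two compounds tested in a functional assay on the whole organism for inhibition, with Rattus norvegicus as the target, read by paw edema, with a stated time of 30 min; a higher number here means that more compound is needed for the effect, a lower number that less compound is needed. In this assay compound 1 gives 62.5 mg/kg, which stands as the higher of the two numbers, while compound 2, `Cc1cc(OCC2=NCCO2)ccc1Cl`, gives 60.2 mg/kg in this assay; the two values lie within the scatter of each other, so nothing separates them. Compound 3, `O=[N+]([O-])c1ccccc1OCC1=NCCO1`, has not yet been measured; it differs from compound 1 by nitro in place of bromo on an aromatic carbon. Within the data shown here, with no comparable step among the measured compounds, the step from compound 1 to compound 3 in this assay is expected to be a 1.0-fold lower number from compound 1 to compound 3 (0.02 log units; within the scatter), that is, nothing beyond the scatter. Compound 3 is therefore estimated to give 60 mg/kg in this assay, within a range from 30 mg/kg to 130 mg/kg.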

Compound 3, dose for half-maximal effect: 70.1 mg/kg
Compound 3: middle estimate off by 1.2-fold (0.07 log units), on the low side, and the stated range covers the measured number.
By their numbers in this assay, from the lowest: compounds 2, 1 and 3 (each within the scatter of the next).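

In this assay, putting nitro in place of bromo on the aromatic carbon ortho to a group of 7 heavy atoms gives a 1.1-fold higher number from compound 1 to compound 3 (0.05 log units; within the scatter) in the core of compound 1. At this position, the assay therefore does not separate these two groups, even though nitro brings more heavy atoms and hydrogen-bond acceptors. No measured evidence explains this result.

From the compounds shown here alone, it remains open whether an amine or a carboxylic acid at this position would move the number beyond the scatter. The compounds shown also do not tell whether nitro and bromo would stay as close on another ring carbon.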